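The compounds below may be only part of what the source reports. "The series", "measured", "known", "first", "only" and "open" are said of these compounds alone.

Three compounds have been measured in a functional assay on HepG2 cells (Homo sapiens) for inhibition, read by MTT assay, with a stated time of 72 h; a higher number here means a weaker inhibitor, a lower number a stronger inhibitor:

compound 1 `C=C(c1ccc(Cl)c(Cl)c1)C1COC2(CCCCC2)OO1`: 83500 nM
compound 2 `C=C(c1ccc(OC)c(F)c1)C1COC(C)(C)OO1`: > 100000 nM (a limit, not a number)
compound 3 `C=C(c1cc(Cl)cc(Cl)c1OCc1ccccc1)C1COC2(CCCC2)OO1`: 13700 nM

Only two of these results are actual numbers. Compound 1 has the higher of them, at 83500 nM. Compound 3 is the nearest, at 13700 nM, and the gap between the two lies beyond the scatter. The result for compound 2 is a limit of the assay: the limit of > 100000 nM in this assay, at which 1 of the 3 values shown sits.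

Compound 4 `C=C(c1ccc(Cl)c(Cl)c1Cl)C1COC2(CCCCC2)OO1` is built from compound 1 by one change: chloro in place of hydrogen on an aromatic carbon, ortho to a chloro group, ortho to a large group and meta to a chloro group (chloro in place of hydrogen on an aromatic carbon). Among the measured compounds shown here, no measured pair isolates such a change, so any expectation is loose. The aromatic ring of compound 1 carries fewer groups than that of compound 3, which gives 13700 nM, though compound 3 differs in other ways too. A modest step towards a lower number is therefore expected in this assay, and it may not exceed the scatter. The expected step is a 1.9-fold lower number from compound 1 to compound 4 (0.27 log units; within the scatter). For compound 4 the estimated value is 45000 nM, with an expected range of 15000 nM to 100000 nM.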

Compound 4, half-maximal inhibitory concentration: 9020 nM
Beside the measured number, compound 4's estimate is 5.0-fold (0.70 log units) above it; measured number below the stated range.
By their numbers in this assay, from the lowest: compounds 4 and 3 (each within the scatter of the next); then compound 1. At a limit, above all of these: compound 2.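

Among the compounds shown here, the addition of chloro in place of hydrogen on an aromatic carbon, ortho to a chloro group, ortho to a large group and meta to a chloro group, gives the first step in this set that isolates a single change: in this assay it is a 9.3-fold lower number from compound 1 to compound 4 (0.97 log units; beyond the scatter). The earlier compounds shown here could not show this, since compound 1, compound 2 and compound 3 differ from one another in more than one place, whereas this step shows that one added chloro at this position of the aromatic ring is enough to move the number beyond the scatter. Nothing measured here accounts for the size of this step.

Whether the size of the step depends on chloro itself stays open, since no other group, such as bromo, a methyl group or an amine, is shown at this position. On these data alone, it also stays open whether the same change would give a step of similar size on compounds that differ from compound 1 elsewhere in the structure, such as compound 3.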